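Benzyl in Place of Methyl on the Selenium Carbon

The compounds below may be only part of what the source reports. "The series", "measured", "known", "first", "only" and "open" are said of these compounds alone.

Compound 2, `C[Se]/C(=N\C(=O)c1cccs1)NC(=O)c1cccs1`, was tested in an ADME assay on MCF-10A cells (Homo sapiens) for cytotoxicity, read by MTT assay, with a stated time of 72 h (a higher number here means a weaker inhibitor of growth, a lower number a stronger inhibitor of growth), and gives 41100 nM. Going by the values given here, that is the higher of the two numbers known here, but compound 1, `CS/C(=N\C(=O)c1sccc1Cl)NC(=O)c1sccc1Cl`, gives 23700 nM, and the two lie within the usual scatter, so no order can be read from them. Compound 3, `O=C(/N=C(/NC(=O)c1cccs1)[Se]Cc1ccccc1)c1cccs1`, has not been measured; it differs from compound 2 by phenyl in place of hydrogen on a saturated chain carbon bound to a selenium atom. Among the compounds with values here, with no measured pair to guide this change, only a small step is expected from compound 2 to compound 3, a 1.6-fold lower number from compound 2 to compound 3 (0.22 log units; within the scatter), probably toward a lower number yet not clearly beyond the scatter. Compound 3 is therefore estimated at 25000 nM, between 8000 nM and 70000 nM.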

Compound 3, concentration for total growth inhibition: > 100000 nM
Compound 3: only a limit was reported; the forecaster's own chance of this, stated with the estimate: 5%; middle value at least 4.0-fold (0.60 log units) from the limit.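

In this assay, going from methyl to benzyl at this position gives an at least 2.4-fold higher number from compound 2 to compound 3 (0.38 log units; beyond the scatter), so this change weakens growth inhibition rather than leaving it unchanged. The value of compound 3, > 100000 nM, is a limit of the assay and not a number. The step is therefore only a minimum, and its full size stays unknown, with this on record: the limit of > 100000 nM in this assay, at which 1 of the 3 values shown sits.

On these data alone, whether an ethyl group or a longer chain in place of the benzyl would shift the number less remains open. So does the effect of an amine on the benzyl.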